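This account rests on a few compounds, and the source may have more. Where it says the series, first, only, none or still open, it means among the compounds named here.

Of the compounds shown here, three sharing one core have been measured in an assay on FRT cells for positive allosteric modulation of Cystic fibrosis transmembrane conductance regulator variant N1303K (Homo sapiens), in the presence of a further agent that is not named here; on this read-out lower numbers stand for an effect already at smaller amounts and higher numbers for an effect only at larger amounts of compound. Compound 1 `COc1ccc2[nH]c3c(c2c1)CCNC31CCN(Cc2ccc([N+](=O)[O-])cc2F)CC1` gives 5900 nM, compound 2 `COc1ccc2[nH]c3c(c2c1)CCNC31CCN(Cc2cc(F)ccc2F)CC1` gives 11100 nM, and compound 3 `COc1ccc2[nH]c3c(c2c1)CCNC31CCN(Cc2cc(F)c(F)c(F)c2)CC1` gives 2600 nM, the lowest of the three numbers. Every step among them swaps the aromatic ring that sits on the saturated chain carbon bound to an amine nitrogen in a ring: a 1.9-fold higher number from compound 1 to compound 2 (0.27 log units; within the scatter), a 2.3-fold lower number from compound 1 to compound 3 (0.36 log units; beyond the scatter) and a 4.3-fold lower number from compound 2 to compound 3 (0.63 log units; beyond the scatter). Compound 4 `COc1ccc2[nH]c3c(c2c1)CCNC31CCN(Cc2cccnc2)CC1` differs from compound 3 in that same place: pyridin-3-yl in place of 3,4,5-trifluorophenyl on a saturated chain carbon bound to an amine nitrogen in a ring. Among the measured compounds shown here, none of the measured steps exchanges a fluorinated ring for a ring holding a nitrogen atom, so those steps bear on this change only by showing that altering this ring shifts the number modestly in either direction, and that compound 3 holds the lowest value among the rings measured. The number for compound 4 is therefore expected to rise modestly, a 2.7-fold higher number from compound 3 to compound 4 (0.43 log units; beyond the scatter). In this assay compound 4 is expected to give about 7000 nM, within a range from 2500 nM to 20000 nM.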

Compound 4, half-maximal effective concentration: 17000 nM
For compound 4 the middle estimate is 2.4-fold (0.39 log units) below the measured one; the measured number falls inside the stated range.
By their numbers in this assay, from the lowest: compound 3; then compounds 1, 2 and 4 (each within the scatter of the next, the first and the last beyond it).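

In this assay, putting pyridin-3-yl in place of 3,4,5-trifluorophenyl gives a 6.5-fold higher number from compound 3 to compound 4 (0.82 log units; beyond the scatter) and thus a ring nitrogen, with no fluorine, does not keep the low number of the trifluorinated ring. Measured against the other rings, the same pyridine ring gives a 2.9-fold higher number from compound 1 to compound 4 (0.46 log units; beyond the scatter) but only a 1.5-fold higher number from compound 2 to compound 4 (0.19 log units; within the scatter) and so a fluorinated ring does not by itself ensure a lower number at this place on a saturated chain carbon bound to an amine nitrogen in a ring. Nothing available here explains these differences.

Still open, from the compounds shown here alone, is whether the ring nitrogen matters in itself or whether the change simply reflects losing the fluorine atoms, a question that a plain phenyl ring could help to separate. Equally open, going by these compounds, is how pyridin-2-yl or pyridin-4-yl compares with pyridin-3-yl here.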